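The source may hold more compounds than are shown below. What is called first, only, known or untested is meant among the compounds shown, and "the series" means these compounds.

Measured so far in a functional assay on MDA-MB-231 cells (Homo sapiens) for inhibition, with a stated time of 72 h; a lower number here means a stronger inhibitor, a higher number a weaker inhibitor:
Compound 1, `O=C(Nc1ccc(Cl)cc1)Nc1nc(Sc2c[nH]c3ccccc23)cc(N2CCCC2)n1`, gives 5850 nM.
Compound 2, `COc1ccc(NC(=O)Nc2nc(Nc3cc(OC)cc(OC)c3)cc(Sc3c[nH]c4ccccc34)n2)cc1`, gives 9460 nM.
Compound 3, `COc1ccc(NC(=O)Nc2nc(Sc3c[nH]c4ccccc34)cc(N3CCCC3)n2)cc1`, gives 13100 nM.

Compound 3 has the highest number of the three, which in this assay means the weakest inhibition. Its gap to compound 2 stays within the scatter (a 1.4-fold higher number from compound 2 to compound 3 (0.14 log units; within the scatter)), so these two cannot be told apart; its gap to compound 1 is a modest one that lies beyond the scatter (a 2.2-fold higher number from compound 1 to compound 3 (0.35 log units; beyond the scatter)).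

Compound 4 is `Cc1cc(Cl)ccc1NC(=O)Nc1nc(Sc2c[nH]c3ccccc23)cc(N2CCCC2)n1`. It differs from compound 3 in one place: 4-chloro-2-methylphenyl in place of 4-methoxyphenyl on an amide-type nitrogen. The shared core, the thioether-linked indole and the pyrrolidine ring stay untouched.

Going by the values given here, one measured step bears on this change. Going from compound 1 to compound 3 swaps chloro for methoxy on the aromatic ring at the urea end, and the number rises modestly (a 2.2-fold higher number from compound 1 to compound 3 (0.35 log units; beyond the scatter)). Among the compounds with values here, compound 4 reverses that swap, putting chloro back, and adds a methyl on the same ring; no measured pair shows what that methyl alone does. A return toward the level of compound 1 is therefore the plain expectation, with the methyl left as an open question.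

Compound 4 is thus expected to reach about 5500 nM in this assay, within a range of 2500 nM to 12000 nM, which corresponds to an estimated step of a 2.4-fold lower number from compound 3 to compound 4 (0.38 log units; beyond the scatter).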

Compound 4, half-maximal inhibitory concentration: 9440 nM
For compound 4 the middle estimate is 1.7-fold (0.23 log units) below the measured one; low and high end bracket the measured number.
By their numbers in this assay, from the lowest: compounds 1, 4, 2 and 3 (each within the scatter of the next, the first and the last beyond it).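

In this assay, 4-chloro-2-methylphenyl in place of 4-methoxyphenyl on the amide-type nitrogen gives a 1.4-fold lower number from compound 3 to compound 4 (0.14 log units; within the scatter), so this larger change at the urea end cannot be told apart from repeat-measurement noise, even though the simpler swap of methoxy for chloro gave a 2.2-fold higher number from compound 1 to compound 3 (0.35 log units; beyond the scatter). The methyl now has its first reading: methyl in place of hydrogen on an aromatic carbon gives a 1.6-fold higher number from compound 1 to compound 4 (0.21 log units; within the scatter), so adding it to compound 1 produces no change that can be resolved, in either direction. Compound 4 therefore cannot be separated from compound 1 or from compound 3, although those two can be separated from each other, and no outside data are available to explain this result.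

From the compounds shown here alone, it remains open whether an ethyl or a trifluoromethyl group in place of this methyl, or a carboxylic acid in place of the chloro, would move the number beyond the scatter. Going by these compounds, it is also open whether the swap of chloro for methoxy would give a similar step when (3,5-dimethoxyphenyl)amino stands in place of pyrrolidin-1-yl.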